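Trading 4-chlorophenyl for 3-methylphenyl

The source may hold more compounds than are shown below. What is called first, only, known or untested is meant among the compounds shown, and "the series" means these compounds.

Measured in a physicochemical assay for solubility, measured as kinetic solubility (a higher number here means a more soluble compound, a lower number a less soluble compound), each value a limit:
Compound 1 `CNC(=O)c1cc(C(=O)N[C@H]2CC[C@H](O)CC2)n([C@@H](C)c2ccc(Cl)cc2)n1`: >= 132 ug/mL
Compound 2 `CNC(=O)c1cc(C(=O)N[C@H]2CC[C@H](O)CC2)c([C@@H](C)c2cccc(C)c2)o1`: >= 172 ug/mL
Compound 3 `CNC(=O)c1cc(C(=O)N[C@H]2CC[C@H](O)CC2)c([C@@H](C)c2ccccc2Cl)o1`: >= 242 ug/mL

Compound 1 has only a limit, >= 132 ug/mL. Compound 4 `CNC(=O)c1cc(C(=O)N[C@H]2CC[C@H](O)CC2)n([C@@H](C)c2cccc(C)c2)n1` keeps the core of compound 1 and changes one group: 3-methylphenyl in place of 4-chlorophenyl on a saturated chain carbon bound to an aromatic nitrogen and a saturated chain carbon. Among the compounds with values here, the only measured step, a step that the two limits leave unreadable from compound 2 to compound 3, offers no size to borrow. Compound 2 also carries 3-methylphenyl, and its limit is >= 172 ug/mL. No change beyond the scatter is therefore expected in this assay, and the estimated step is a step that the limit leaves unreadable from compound 1 to compound 4. The expected value for compound 4 is 165 ug/mL, with an estimated range from 85 ug/mL to 270 ug/mL.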

Compound 4, solubility: >= 180 ug/mL
Compound 4: a limit, no number; the forecaster's own chance of this, stated with the estimate: 65%; middle value at least 1.0-fold (0.03 log units) from the limit.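

In this assay, within the data shown here, compound 1 and compound 4 each give only a limit, and no step between them can be read. On these data alone, whether 3-methylphenyl in place of 4-chlorophenyl changes this read-out at all stays open.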